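Furan-2-yl in place of quinolin-4-yl on a carbonyl carbon

The source may hold more compounds than are shown below. What is called first, only, known or untested is meant among the compounds shown, and "the series" means these compounds.

In a functional assay on NCI-H460 cells (Homo sapiens) for antiproliferative activity (a higher number here means a weaker inhibitor, a lower number a stronger inhibitor), compound 1 `COc1ccc(S(=O)(=O)Oc2ccccc2NC(=O)c2ccncc2)cc1` gives 55 nM. Compound 3 `COc1ccc(S(=O)(=O)Oc2ccccc2NC(=O)c2ccnc3ccccc23)cc1` reads > 10000 nM, which is a limit and not a number. Compound 2 `COc1ccc(S(=O)(=O)Oc2ccccc2NC(=O)Nc2ccccc2)cc1` reads > 10000 nM, also a limit. Compound 3 and compound 2 both stand at the limit of > 10000 nM in this assay, at which 2 of the 3 values shown sit.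

Compound 4 `COc1ccc(S(=O)(=O)Oc2ccccc2NC(=O)c2ccco2)cc1` is not yet measured. It carries furan-2-yl in place of quinolin-4-yl on a carbonyl carbon.

Two large steps at this same carbon bear on the change. Quinolin-4-yl in place of pyridin-4-yl gives an at least 180-fold higher number from compound 1 to compound 3 (2.25 log units; beyond the scatter), and anilino in place of pyridin-4-yl gives an at least 180-fold higher number from compound 1 to compound 2 (2.25 log units; beyond the scatter). The step that the two limits leave unreadable from compound 2 to compound 3 adds nothing readable. Within the data shown here, only the pyridin-4-yl group has a number so far, so recovery of activity is expected to be partial, and compound 4 may also end at the limit. The expected change, toward a lower number, is an at least 3.3-fold lower number from compound 3 to compound 4 (0.52 log units; beyond the scatter). For compound 4 the estimated value is 3000 nM, with an expected range of 300 nM to 10000 nM.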

Compound 4, half-maximal inhibitory concentration: 24 nM
Compound 4: the middle estimate sits 130-fold (2.10 log units) above what was measured, outside the stated range (below it).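

In this assay activity at this carbonyl carbon turns out not to be tied to pyridin-4-yl or to a ring nitrogen: furan-2-yl gives a 2.3-fold lower number from compound 1 to compound 4 (0.36 log units; beyond the scatter) and leaves compound 4 with the lowest number of the four shown. Furan-2-yl also gives an at least 410-fold lower number from compound 3 to compound 4 (2.61 log units; beyond the scatter) and an at least 410-fold lower number from compound 2 to compound 4 (2.61 log units; beyond the scatter) and so shows that the two-ring quinolin-4-yl is poorly tolerated here while two single-ring aromatic groups are, with anilino going against any reading by ring count alone. Compound 2 and compound 3 are read only as limits of the assay, not as numbers: the limit of > 10000 nM in this assay, at which 2 of the 4 values shown sit.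

Still open, as far as these compounds go, is whether the ring oxygen of furan-2-yl matters, which a thiophen-2-yl or plain phenyl group would test. Also open, from the compounds shown here alone, is whether any aromatic ring is needed on this carbonyl carbon, which a cyclopropyl group would test.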